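The source may hold more compounds than are shown below. What is called first, only, known or untested is meant among the compounds shown, and "the series" means these compounds.

Measured so far:
Compound 1, `COc1cccc(Oc2ccc3c(NCCCNCc4cccc(OC)c4O)ccnc3c2)c1`; in a physicochemical assay for acid dissociation, compound 1 gives 9.28.
Compound 2, `COc1cccc(CNCCCNc2ccnc3cc(-c4ccccc4)ccc23)c1O`; in this assay compound 2 gives 9.47.

Within the data shown here, compound 2 holds the higher of the two numbers, but its only neighbour is compound 1, and the step of a number 0.19 log units higher from compound 1 to compound 2 (within the scatter) is within the scatter, so no order between the two can be claimed. Compound 3 is `COc1cccc(CNCCCNc2ccnc3cc(CC(C)C)ccc23)c1O`. It differs from compound 2 in one place: isobutyl in place of phenyl on an aromatic carbon. Among the measured compounds shown here, the one measured step that bears on this is the earlier change at the same aromatic carbon of the shared core, a number 0.19 log units higher from compound 1 to compound 2 (within the scatter), which stayed within the scatter. On that single precedent, another swap at this carbon is expected to leave this assay largely unchanged, with a step of a number 0.03 log units higher from compound 2 to compound 3 (within the scatter) expected. Compound 3 is therefore estimated at 9.5, with a range from 9.1 to 9.9.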

Compound 3, acid dissociation constant: 9.47
Beside the measured number, compound 3's estimate is 0.03 log units above it; low and high end bracket the measured number.
By their numbers in this assay, from the lowest: compounds 1, 2 and 3 (each within the scatter of the next).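

In this assay, among these compounds, the step of no change at the digits printed from compound 2 to compound 3 (within the scatter) is the first at this aromatic carbon in which a group with no ring, isobutyl, takes the place of a group carrying a six-membered aromatic ring, phenyl. Set against 3-methoxyphenoxy, isobutyl gives a number 0.19 log units higher from compound 1 to compound 3 (within the scatter), so all three groups at this carbon lie within the scatter of one another, and a ring at this carbon is not needed for a number of this size. Nothing available here explains this result.

As far as these compounds go, whether an amine or a carboxylic acid on this same carbon would give a number beyond the scatter remains open. So does whether a longer chain between the two nitrogens of the shared core would do so.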